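Trimethoxyphenyl series: chloro placement on the pendant phenyl

The source may report more compounds than this note shows. Statements on the series, on what has been measured and on what is new or still open speak of the compounds shown alone.

Measured so far:
compound 1 `COc1cc(-n2cnc3ccc(-c4ccc([N+](=O)[O-])cc4)cc32)cc(OC)c1OC`: 8940 nM
compound 2 `COc1cc(-n2cnc3ccc(-c4ccc(Cl)cc4)cc32)cc(OC)c1OC`: > 10000 nM
compound 3 `COc1cc(-n2cnc3ccc(-c4ccc(Cl)cc4Cl)cc32)cc(OC)c1OC`: > 10000 nM

In a functional assay on A549 cells (Homo sapiens) for antiproliferative activity, read by MTT assay, with a stated time of 72 h (on this read-out lower numbers stand for stronger inhibition and higher numbers for weaker inhibition), compound 1 gives 8940 nM. Compound 2 reaches only the limit of this assay, > 10000 nM. Compound 3 likewise gives only the limit, > 10000 nM. Compound 3 therefore stands at the weak end of what has been measured, sharing the position described by the limit of > 10000 nM in this assay, at which 2 of the 3 values shown sit, with compound 2. The measured steps read an at least 1.1-fold higher number from compound 1 to compound 3 (0.04 log units; that floor lies within the scatter) and a step that the two limits leave unreadable from compound 2 to compound 3; neither resolves the chloro-bearing compounds against each other.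

Compound 4 `COc1cc(-n2cnc3ccc(-c4cccc(Cl)c4)cc32)cc(OC)c1OC` carries the change (3-chlorophenyl in place of 2,4-dichlorophenyl on an aromatic carbon). The step that bears on it most directly is a step that the two limits leave unreadable from compound 2 to compound 3, which is unreadable, and both chloro-bearing compounds sit at the limit. Nothing measured separates one chloro position on the pendant phenyl from another. The expectation for compound 4 is therefore a number near the limit again, with a step that the limit leaves unreadable from compound 3 to compound 4 expected to stay within the scatter. Compound 4 is estimated at 12000 nM, expected between 5000 nM and 30000 nM.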

Compound 4, half-maximal inhibitory concentration: 7050 nM
Estimate against measurement, compound 4: 1.7-fold (0.23 log units) above, within the range that was stated.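

In this assay, going by these compounds alone, compound 4 is the first chloro-bearing compound of the series to give a number, so a chloro group on the pendant phenyl does not in itself hold a compound at the limit. The readings are an at least 1.4-fold lower number from compound 3 to compound 4 (0.15 log units; that floor lies within the scatter) and an at least 1.4-fold lower number from compound 2 to compound 4 (0.15 log units; that floor lies within the scatter), so the position of the chloro group is not yet shown to matter beyond the scatter. The reading a 1.3-fold lower number from compound 1 to compound 4 (0.10 log units; within the scatter) leaves 3-chlorophenyl and 4-nitrophenyl indistinguishable at this position, and the other two chloro compounds still give only a limit: the limit of > 10000 nM in this assay, at which 2 of the 4 values shown sit.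

Open, on these data alone, is how far compound 2 and compound 3 truly lie from compound 4. Also open, as far as these compounds go, is whether an amine or a carboxylic acid on the pendant phenyl would give a step beyond the scatter.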